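Two Unsaturated Amides on a Shared Core

The compounds below may be only part of what the source reports. "The series", "measured", "known", "first", "only" and "open" are said of these compounds alone.

The series rests on one shared core carrying an amide-bearing aryl ether on one side and an amino-substituted ring on the other. Compound 1 `CCC/C=C/C(=O)Nc1cccc(Oc2nc(Nc3ccn(C)n3)nc3c2CSCC3)c1` is the reference point; in a functional assay on HeLa cells (Homo sapiens) for antiproliferative activity, read by MTT assay, with a stated time of 72 h (a lower number here means a stronger inhibitor, a higher number a weaker inhibitor), compound 1 gives 17000 nM. Compound 2 `CC(C)=CC(=O)Nc1cccc(Oc2nc(Nc3ccn(C)n3)nc3c2CSCC3)c1` differs from compound 1 by 2-methylprop-1-en-1-yl in place of pent-1-en-1-yl on a carbonyl carbon. For compound 2 the assay records only a limit, > 50000 nM, which is the limit described as the limit of > 50000 nM in this assay, at which 1 of the 3 values shown sits. The step of an at least 2.9-fold higher number from compound 1 to compound 2 (0.46 log units; beyond the scatter) is therefore known only as a lower bound on its size.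

Compound 3 `CCC/C=C/C(=O)Nc1cccc(Oc2nc(Nc3ccc(OC)cc3)nc3c2CSCC3)c1` differs from compound 1 in the other half of the molecule, by 4-methoxyphenyl in place of 1-methyl-1H-pyrazol-3-yl on a nitrogen on an aromatic ring. In this assay compound 3 gives 12800 nM, and the step of a 1.3-fold lower number from compound 1 to compound 3 (0.12 log units; within the scatter) does not separate the two compounds.

Compound 4 `COc1ccc(Nc2nc3c(c(Oc4cccc(NC(=O)C=C(C)C)c4)n2)CSCC3)cc1` has not yet been measured. It differs from compound 3 by 2-methylprop-1-en-1-yl in place of pent-1-en-1-yl on a carbonyl carbon, and the surroundings of the change are the same as those between compound 1 and compound 2, so this is the same change. Compound 4 is expected to show a step of a 3.5-fold higher number from compound 3 to compound 4 (0.55 log units; beyond the scatter), placed beside the earlier step of an at least 2.9-fold higher number from compound 1 to compound 2 (0.46 log units; beyond the scatter), because the same change from compound 1 gave the loss seen in an at least 2.9-fold higher number from compound 1 to compound 2 (0.46 log units; beyond the scatter). The estimate for compound 4 is 45000 nM, with a range from 25000 nM to 100000 nM, and there is a real chance that the assay again reports only a limit.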

Compound 4, half-maximal inhibitory concentration: 19100 nM
Beside the measured number, compound 4's estimate is 2.4-fold (0.37 log units) above it; the measured number lies below the stated range.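

In this assay, the change from pent-1-en-1-yl to 2-methylprop-1-en-1-yl on the carbonyl carbon now gives a 1.5-fold higher number from compound 3 to compound 4 (0.17 log units; within the scatter), so on this core the change does not separate the pair, and the earlier step does not carry over as a clear loss; it also cannot be said that the change behaves differently on the two cores: the same change on two cores in this assay, an at least 2.9-fold higher number (0.46 log units; beyond the scatter) from compound 1 to compound 2 and a 1.5-fold higher number (0.17 log units; within the scatter) from compound 3 to compound 4; the limit leaves it open whether they differ. The second change, 4-methoxyphenyl in place of 1-methyl-1H-pyrazol-3-yl on the nitrogen, gives an at least 2.6-fold lower number from compound 2 to compound 4 (0.41 log units; beyond the scatter), but this does not show that its size depends on the amide group: the same change on two cores in this assay, a 1.3-fold lower number (0.12 log units; within the scatter) from compound 1 to compound 3 and an at least 2.6-fold lower number (0.41 log units; beyond the scatter) from compound 2 to compound 4; the limit leaves it open whether they differ. Both comparisons turn on compound 2, whose entry is a limit and not a number: the limit of > 50000 nM in this assay, at which 1 of the 4 values shown sits.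

On these data alone, the true size of the step to compound 2 stays open, and with it the question of whether this change transfers from one core to the other with the same size. The compounds shown also leave open how a longer chain on the carbonyl carbon, or a terminal amine on that chain, would behave on either core.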